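Chain terminus on the shared core: alkene to alkyne

A few compounds are considered here, and "the series" means these few. Any claim that something is new, unique, unknown or untested is made for them only; others in the source may bear on it.

Compound 1 `C=CCCCc1cc2cn([C@H]3C[C@H](O)[C@@H](CO)O3)c(=O)nc2o1` carries the shorter chain on the shared core. In a functional assay on HEL cells (Homo sapiens) for cytotoxicity (on this read-out lower numbers stand for higher toxicity in this test and higher numbers for lower toxicity in this test), compound 1 reaches only the limit of > 200000 nM. Compound 2 `C=CCCCCCCCCc1cc2cn([C@H]3C[C@H](O)[C@@H](CO)O3)c(=O)nc2o1` carries the longer chain, hept-6-en-1-yl in place of vinyl on a saturated chain carbon, three bonds along the chain from an aromatic carbon. In this assay compound 2 likewise reaches only the limit of > 200000 nM. Going by the values given here, the step that the two limits leave unreadable from compound 1 to compound 2 is therefore unreadable; the only evidence the pair offers is the limit of > 200000 nM in this assay, at which 2 of the 2 values shown sit.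

Compound 3 `C#CCCCCCc1cc2cn([C@H]3C[C@H](O)[C@@H](CO)O3)c(=O)nc2o1` differs from compound 2 by ethynyl in place of pent-4-en-1-yl on a saturated chain carbon, five bonds along the chain from an aromatic carbon. Compound 2 thus stands at the upper limit of this assay, not at a number. Among the compounds with values here, no measured step bears on the change to compound 3: the single step cannot be read, and both measured values sit at the limit. No shift beyond the scatter is expected, and the step of a number no higher from compound 2 to compound 3 (the limit leaves the size open) is an estimate resting on the two limits alone. Compound 3 is expected to give 200000 nM, within 100000 nM to 400000 nM, most likely again reported only as a limit.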

Compound 3, half-maximal cytotoxic concentration: > 200000 nM
Compound 3 was reported as a limit; the forecaster's own chance of this, stated with the estimate: 85%; the middle value lies on the limit itself.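

Compound 1, compound 2 and compound 3 all stand at a limit in this assay, not at a number, so none of the steps among them can be read: the limit of > 200000 nM in this assay, at which 3 of the 3 values shown sit.

The compounds shown leave open whether chain length or an alkene or alkyne chain terminus on the shared core changes this read-out at all.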